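Removing the Hydroxy Group: Expected Cell Tolerance of Compound 4

A few compounds are considered here, and "the series" means these few. Any claim that something is new, unique, unknown or untested is made for them only; others in the source may bear on it.

Compound 1 `COc1ccc(-c2cnc(NC(=O)c3ccccc3O)n2C)cc1` is one of three amides built on a shared core. In a toxicity assay on THP-1 cells (Homo sapiens) for inhibition (a lower number here means that less compound is tolerated, a higher number that more compound is tolerated), compound 1 gives > 100000 nM, which is a limit of the assay rather than a number. Compound 2 `Cn1c(-c2ccc(F)cc2)cnc1NC(=O)c1ccc(F)cc1` likewise reaches a limit, giving > 100000 nM in this assay. Among the measured compounds shown here, compound 3 `Cn1c(-c2ccccc2[N+](=O)[O-])cnc1NC(=O)c1ccc(F)cc1` is the only member with a numeric value, giving 31000 nM in this assay. Compound 1 thus stands at the ceiling of what this assay reports, together with compound 2 (the limit of > 100000 nM in this assay, at which 2 of the 3 values shown sit). For the measured compounds named here, no step between measured compounds differing in one place is available, so the set offers two limits and one number.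

Compound 4 `COc1ccc(-c2cnc(NC(=O)c3ccccc3)n2C)cc1` differs from compound 1 in one place: hydrogen in place of hydroxy on an aromatic carbon. Compound 1 is known only as a limit, so the step to compound 4 cannot be laid against a measured number; the step of a number no higher from compound 1 to compound 4 (the limit leaves the size open) is expected to be none beyond the scatter in this assay. Compound 4 is therefore estimated at 100000 nM, within a range of 30000 nM to 300000 nM, most likely again as a limit.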

Compound 4, half-maximal cytotoxic concentration: > 100000 nM
Compound 4 ended at the assay's limit; the forecaster's own chance of this, stated with the estimate: 70%; the middle value sits exactly at the limit.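

Compound 1 and compound 4 both stand at a limit in this assay, so no step between them can be read: the limit of > 100000 nM in this assay, at which 3 of the 4 values shown sit.

The compounds shown leave open whether hydrogen in place of hydroxy on an aromatic carbon changes cell tolerance at all; neither compound 1 nor compound 4 has a numeric value.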